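Sulfonamide piperidines in a cytotoxicity assay

The compounds below may be only part of what the source reports. "The series", "measured", "known", "first", "only" and "open" are said of these compounds alone.

Compound 1 `CC1CCN(C2CCN(S(=O)(=O)c3sc(Cl)nc3C3CC3)CC2)CC1` is measured in an ADME assay on HCT-116 cells (Homo sapiens) for cytotoxicity, read by CellTiter-Glo, with a stated time of 72 h; a higher number here means a weaker inhibitor, a lower number a stronger inhibitor; compound 1 gives > 10000 nM, a limit of the assay. Compound 2 `Cc1cc(C)c(S(=O)(=O)N2CCC(C(=O)N3CCC(C)CC3)CC2)c(C)c1` gives > 5000 nM in this assay, likewise only a limit. Both values shown are limits (the limit of > 10000 nM in this assay, at which 1 of the 2 values shown sits, (the limit of > 5000 nM in this assay, at which 1 of the 2 values shown sits)), so compound 2 cannot be ranked against compound 1. Compound 3 `Cc1cc(C)c(S(=O)(=O)N2CCC(N3CCC(C(C)C)CC3)CC2)c(C)c1` differs from compound 2 by 4-isopropylpiperidin-1-yl in place of (4-methylpiperidin-1-yl)carbonyl on a saturated ring carbon. Among the measured compounds shown here, no measured step between neighbours exists, so no shift in this assay beyond the scatter is expected for this change. Compound 3 is expected at 10000 nM in this assay, between 3000 nM and 30000 nM, most likely reported again as a limit. The expected step is a step that the limit leaves unreadable from compound 2 to compound 3.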

Compound 3, half-maximal inhibitory concentration: > 5000 nM
Compound 3 was reported as a limit; the forecaster's own chance of this, stated with the estimate: 75%; the middle value lies beyond the limit too.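

No step can be read between compound 2 and compound 3 in this assay, as both values are limits: the limit of > 5000 nM in this assay, at which 2 of the 3 values shown sit.

The compounds shown leave open whether 4-isopropylpiperidin-1-yl in place of (4-methylpiperidin-1-yl)carbonyl shifts the half-maximal inhibitory concentration at all.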